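The compounds below may be only part of what the source reports. "The series", "measured", "known", "first", "only" and "open" are said of these compounds alone.

Compound 1 `C=CCCCCCCCCC(=O)Nc1cc2c(cc1F)c(=O)c(C(=O)OCC)cn2CC`: 87300 nM
Compound 2 `CCCCCC(=O)Nc1cc2c(cc1F)c(=O)c(C(=O)OCC)cn2CC`: 9800 nM

In a functional assay on DU-145 cells (Homo sapiens) for cytotoxicity, read by MTT assay (a higher number here means a weaker inhibitor, a lower number a stronger inhibitor), compound 2 gives the lower of the two numbers. Going by the values given here, the only measured step is an 8.9-fold lower number from compound 1 to compound 2 (0.95 log units; beyond the scatter), in which pent-4-en-1-yl was dropped from the amide chain. Compound 3 `CCCCCCCCCCCCCCCCCC(=O)Nc1cc2c(cc1F)c(=O)c(C(=O)OCC)cn2CC` goes the other way with the change (dodecyl in place of hydrogen on a saturated chain carbon, five bonds along the chain from a carbonyl carbon), a chain longer than that of compound 1. Because of an 8.9-fold lower number from compound 1 to compound 2 (0.95 log units; beyond the scatter), a higher number, and so weaker inhibition, is expected for compound 3, probably by a larger margin than that step. The expected step is a 20-fold higher number from compound 2 to compound 3 (1.31 log units; beyond the scatter). Compound 3 is therefore estimated at 200000 nM, in the range 40000 nM to 1000000 nM.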

Compound 3, half-maximal inhibitory concentration in the DU-145 assay: 37100 nM
Beside the measured number, compound 3's estimate is 5.4-fold (0.73 log units) above it, and the stated range ends above it.
By their numbers in the DU-145 assay, from the lowest: compound 2; then compound 3; then compound 1.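

In the DU-145 assay, a longer chain at this position does not simply mean weaker inhibition: there is a 3.8-fold higher number from compound 2 to compound 3 (0.58 log units; beyond the scatter), yet also a 2.4-fold lower number from compound 1 to compound 3 (0.37 log units; beyond the scatter), so the compound with the longest chain is not the weakest of the three. The dodecyl change also raises the number in a physicochemical assay (on this read-out higher numbers stand for an effect only at larger amounts of compound and lower numbers for an effect already at smaller amounts), where compound 2 gives 33.8 ug/mL and compound 3 gives 799 ug/mL. The compounds shown leave open how much of the number of compound 1 comes from its terminal vinyl rather than its chain length, and how an amine or a carboxylic acid at the chain end would read in the DU-145 assay.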